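The compounds below may be only part of what the source reports. "The series", "measured", "known", "first", "only" and "open" are said of these compounds alone.

Notes on the series. Of the compounds shown here, three have been measured in a functional assay on the whole organism with Mus musculus as the target; a lower number here means that less compound is needed, a higher number that more compound is needed for the effect. Compound 1 `Cc1ccc(C(=N)Nn2c(C)nnc2C)cc1` gives > 600 mg/kg, which is a limit of the assay rather than a number. Compound 2 `CCc1nnc(CC)n1/N=C(\N)c1ccc(Cl)cc1` likewise gives only a limit, > 600 mg/kg. Compound 3 `CC(=O)n1nc(-c2ccc(C)cc2)nc1C` also returns only a limit, > 600 mg/kg. Compound 3 therefore stands together with the other two at the limit of > 600 mg/kg in this assay, at which 3 of the 3 values shown sit, and no order among the three can be read from these values. Going by the values given here, no step between measured compounds that differ in one place is available. The unmeasured compound 4 `CC(=O)n1nc(-c2ccc(C(F)(F)F)cc2)nc1C` differs from compound 3 by trifluoromethyl in place of methyl on an aromatic carbon. With every measured value a limit, no step beyond the scatter is expected in this assay from compound 3 to compound 4 a number no higher from compound 3 to compound 4 (the limit leaves the size open). Compound 4 is expected to give around 600 mg/kg in this assay, between 300 mg/kg and 1200 mg/kg, most probably again reported only as a limit.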

Compound 4, dose for 50% inhibition: 411 mg/kg
Estimate against measurement, compound 4: 1.5-fold (0.16 log units) above, and the stated range covers the measured number.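

Trifluoromethyl in place of methyl on an aromatic carbon gives the first step that can be read at this position in this assay, with an at least 1.4-fold lower number from compound 3 to compound 4 (0.16 log units; that floor lies within the scatter). Compound 4 is also the first compound shown with a number rather than a limit, but the floor of this step does not clear the scatter, so the change cannot yet be called a real gain. The other three compounds offer no number to compare with: the limit of > 600 mg/kg in this assay, at which 3 of the 4 values shown sit.

Going by these compounds, the true size of the step remains open, since compound 3 has only a limit. Also open, on these data alone, is what an amine, a carboxylic acid or a longer chain would give at this position.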